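The compounds below may be only part of what the source reports. "The series", "measured", "known", "first", "only" and "open" are said of these compounds alone.

Working notes on the series

The series is tested in a functional assay on RAW264.7 cells (Mus musculus) for inhibition, read by microscopy and resazurin assay, with a stated time of 72 h; a lower number here means a stronger inhibitor, a higher number a weaker inhibitor. Compound 1 `C=CCONC(=O)CN1C(=O)S/C(=C\c2ccc(C(=O)N[C@H](C(=O)OC)C(C)C)cc2)C1=O` carries an allyloxy amide on the shared core. In this assay compound 1 reaches only the limit > 128000 nM. Compound 2 `COC(=O)[C@@H](NC(=O)c1ccc(/C=C2\SC(=O)N(CC(=O)NOCc3ccccc3)C2=O)cc1)C(C)C` differs from compound 1 by phenyl in place of vinyl on a saturated chain carbon bound to an oxygen on an unsaturated carbon. In this assay compound 2 also reaches only the limit > 128000 nM. The step that the two limits leave unreadable from compound 1 to compound 2 therefore cannot be read as a number; both compounds sit at the limit of > 128000 nM in this assay, at which 3 of the 3 values shown sit.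

Compound 3 `C=CCONC(=O)CN1C(=O)S/C(=C\c2cccc(C(=O)N[C@H](C(=O)OC)C(C)C)c2)C1=O` is built from the same atoms as compound 1, joined differently; the difference between the two cores is not broken down here. In this assay compound 3 reaches only the limit > 128000 nM.

Compound 4 `COC(=O)[C@@H](NC(=O)c1cccc(/C=C2\SC(=O)N(CC(=O)NOCc3ccccc3)C2=O)c1)C(C)C` is not yet measured. Compound 4 differs from compound 3 by phenyl in place of vinyl on a saturated chain carbon bound to an oxygen on an unsaturated carbon, which is the same change that turns compound 1 into compound 2, at the same place on the chain. The earlier occurrence of this change gave no readable size, since compound 1 and compound 2 both stood at the limit of > 128000 nM in this assay, at which 3 of the 3 values shown sit. The step from compound 3 to compound 4 is expected to be a step that the limit leaves unreadable from compound 3 to compound 4, meaning no measurable movement, because compound 3 already stands at > 128000 nM and the same change left compound 2 at the limit of > 128000 nM in this assay, at which 3 of the 3 values shown sit. Compound 4 is therefore estimated to give 200000 nM in this assay, most likely reported as a limit only, with a range from 100000 nM to 600000 nM.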

Compound 4, half-maximal inhibitory concentration: > 128000 nM
Compound 4: only a limit was reported; the forecaster's own chance of this, stated with the estimate: 85%; the middle value does not contradict the limit.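

No new step can be read in this assay, since compound 3 and compound 4 are both reported only as limits and the change from allyloxy to benzyloxy has no readable size. All the compounds shown share one limit: the limit of > 128000 nM in this assay, at which 4 of the 4 values shown sit. The compounds shown leave open whether either change, allyloxy to benzyloxy or the rearrangement between the cores of compound 1 and compound 3, affects inhibition in this assay.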